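The source may report more compounds than this note shows. Statements on the series, on what has been measured and on what is new or still open speak of the compounds shown alone.

Measured in a functional assay on HeLa cells (Homo sapiens) for cytotoxicity, read by MTT assay, with a stated time of 72 h; a higher number here means a weaker inhibitor, a lower number a stronger inhibitor:
Compound 1 `CN1CCN(Cc2nnc(-c3cc(S(N)(=O)=O)c(SCc4ccccc4)cc3Cl)o2)CC1` gives 75000 nM.
Compound 2 `NC(=O)c1cn(Cc2nnc(-c3cc(S(N)(=O)=O)c(SCc4ccccc4)cc3Cl)o2)nn1` gives 75000 nM.
Compound 3 `CC(C)(O)c1cn(Cc2nnc(-c3cc(S(N)(=O)=O)c(SCc4ccccc4)cc3Cl)o2)nn1` gives 68000 nM.

Compound 3 stands among three numbers that all lie within the scatter of one another: a 1.1-fold lower number from compound 1 to compound 3 (0.04 log units; within the scatter) and a 1.1-fold lower number from compound 2 to compound 3 (0.04 log units; within the scatter). Compound 4 `NS(=O)(=O)c1cc(-c2nnc(Cn3cc(-c4ccccc4)nn3)o2)c(Cl)cc1SCc1ccccc1` is not yet measured; it differs from compound 3 by phenyl in place of 1-hydroxy-1-methylethyl on an aromatic carbon. The step that bears most directly on this change is the one at the same ring carbon, a 1.1-fold lower number from compound 2 to compound 3 (0.04 log units; within the scatter), and the wider swaps of the whole group, no change at the digits printed from compound 1 to compound 2 (within the scatter) and a 1.1-fold lower number from compound 1 to compound 3 (0.04 log units; within the scatter), were likewise within the scatter. Compound 4 is therefore expected to show no step beyond the scatter, a 1.0-fold higher number from compound 3 to compound 4 (0.01 log units; within the scatter). For compound 4 the estimate in this assay is 70000 nM, with a range from 30000 nM to 160000 nM.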

Compound 4, half-maximal inhibitory concentration: 7000 nM
Beside the measured number, compound 4's estimate is 10-fold (1.00 log units) above it; measured number outside the range, below it.
By their numbers in this assay, from the lowest: compound 4; then compounds 3, 1 and 2 (each within the scatter of the next).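

In this assay the group on this aromatic carbon proves able to shift the number: a 9.7-fold lower number from compound 3 to compound 4 (0.99 log units; beyond the scatter) comes with phenyl replacing 1-hydroxy-1-methylethyl and an 11-fold lower number from compound 2 to compound 4 (1.03 log units; beyond the scatter) with phenyl replacing carbamoyl, although those two earlier groups lay within the scatter of each other. Similarly, an 11-fold lower number from compound 1 to compound 4 (1.03 log units; beyond the scatter) accompanies 4-phenyl-1H-1,2,3-triazol-1-yl replacing 4-methylpiperazin-1-yl, and since compound 2 and compound 3 also carry the triazolyl link, that link alone does not account for the step. No evidence is available that explains this result.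

Going by these compounds, only compound 4 carries a ring on this carbon, so whether a cyclohexyl or a pyridyl group would serve as phenyl does remains open. So does the effect of a methoxy group or a chlorine on the phenyl ring.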